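The source may report more compounds than this note shows. Statements on the series, on what has been measured and on what is new or still open speak of the compounds shown alone.

Measured so far:
compound 1, `CC(=O)N[C@@H](C)C(=O)N(C)/N=N/c1ccc(C(N)=O)cc1`: 7.6 h
compound 2, `CCCC(=O)N[C@@H](C)C(=O)N(C)/N=N/c1ccc(C#N)cc1`: 1.1 h

Both compounds were tested in an ADME assay on a cell-free system (plasma, Homo sapiens) for metabolic stability, read by HPLC; on this read-out lower numbers stand for a shorter-lived compound and higher numbers for a longer-lived compound. Compound 1 gives 7.6 h and stands highest of the two numbers; the nearest is compound 2, which gives 1.1 h, a gap beyond the scatter. Among the compounds with values here, compound 2 differs from compound 1 in two places at once, so these two values show only that the compounds differ, not which change carries the difference.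

Compound 3, `CC(=O)N[C@@H](C)C(=O)N(C)/N=N/c1ccc(C)cc1`, has not yet been measured. It differs from compound 1 by methyl in place of carbamoyl on an aromatic carbon. Within the data shown here, no pair of measured compounds differs in a single place, so there is no measured step to lean on. The expected step is a 1.7-fold lower number from compound 1 to compound 3 (0.23 log units; within the scatter) in this assay, a modest move downward that may well lie within the scatter. Compound 3 is estimated at 4.5 h, with a range from 1.5 h to 12 h.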

Compound 3, half-life in the plasma assay: 15.1 h
For compound 3 the middle estimate is 3.4-fold (0.53 log units) below the measured one; measured number above the stated range.
By their numbers in the plasma assay, from the lowest: compound 2; then compounds 1 and 3 (each within the scatter of the next).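

Within the data shown here, this is the first comparison that changes a single place, and in the plasma assay it gives a 2.0-fold higher number from compound 1 to compound 3 (0.30 log units; within the scatter), so the two compounds cannot be told apart on half-life. Removing the carbamoyl group, with its hydrogen-bond donor and acceptor, therefore does not shorten the half-life beyond the scatter in this pair. In a physicochemical assay for lipophilicity, read by HPLC, in phosphate buffer, measured as octanol-water partition, at pH 7.4 (a higher number here means a more lipophilic compound, a lower number a more polar compound), compound 1 gives 0.69 and compound 3 gives 2.45. The same exchange is far from neutral in the physicochemical assay, which shows that a large move in this read-out can come without a clear move in half-life, at least for this one pair: the measured partition coefficient of compound 1, 0.69, and of compound 3, 2.45, a number 1.76 log units higher (beyond the scatter)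

Going by these compounds, whether other groups on this aromatic carbon, such as a carboxylic acid or an amine, would leave the half-life just as undisturbed remains open. Also open, on these data alone, is which part of the shared core sets the half-life in plasma.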